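The source may report more compounds than this note shows. Statements on the series, on what has been measured and on what is new or still open speak of the compounds shown alone.

Working notes on the series. In an ADME assay on L02 cells (Homo sapiens) for cytotoxicity, read by MTT assay, with a stated time of 48 h (on this read-out lower numbers stand for stronger inhibition and higher numbers for weaker inhibition), compound 1 (`CCN(CC)CCNC(=O)c1ccc(C(CC)(CC)c2ccc(OCC(=O)C(C)(C)C)c(C)c2)n1CC`) gives 2500 nM. Compound 2 (`CCN(CC)CCNC(=O)c1ccc(C(CC)(CC)c2ccc(OCC(O)C(C)(C)C)c(C)c2)n1CC`) gives 2500 nM, and compound 3 (`C#CCNC(=O)c1ccc(C(CC)(CC)c2ccc(OCC(O)C(C)(C)C)c(C)c2)n1CC`) gives 4400 nM. Compound 1 thus stands level with compound 2 and within the scatter of compound 3.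

The next structure is compound 4 (`CCn1c(C(=O)N(C)CC(=O)O)ccc1C(CC)(CC)c1ccc(OCC(=O)C(C)(C)C)c(C)c1`), which keeps the core of compound 1 and its (tert-butyl)carbonyl group. On a carbonyl carbon, (carboxymethyl)(methyl)amino stands in place of (2-(diethylamino)ethyl)amino: (carboxymethyl)(methyl)amino in place of (2-(diethylamino)ethyl)amino on a carbonyl carbon.

Two measured steps are available. no change at the digits printed from compound 1 to compound 2 (within the scatter) concerns a different part of the structure and bears on this change only weakly. a 1.8-fold higher number from compound 2 to compound 3 (0.25 log units; within the scatter) is the closer guide, as it also removes the (diethylamino)methyl group. However, no measured compound carries (carboxymethyl)(methyl)amino, so the effect of the entering group is untested in this assay.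

The size of the step from compound 2 to compound 3 suggests a modest move towards a higher number, with a wide margin for the new group. The expected step is a 3.6-fold higher number from compound 1 to compound 4 (0.56 log units; beyond the scatter). The estimated value for compound 4 is 9000 nM, with an expected range of 3500 nM to 30000 nM.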

Compound 4, half-maximal inhibitory concentration: 8700 nM
Beside the measured number, compound 4's estimate is 1.0-fold (0.01 log units) above it; low and high end bracket the measured number.
By their numbers in this assay, from the lowest: compounds 1, 2, 3 and 4 (each within the scatter of the next, the first and the last beyond it).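

In this assay, (carboxymethyl)(methyl)amino in place of (2-(diethylamino)ethyl)amino on a carbonyl carbon gives a 3.5-fold higher number from compound 1 to compound 4 (0.54 log units; beyond the scatter), with the core and the (tert-butyl)carbonyl group kept. Among the compounds shown here, the group on this carbonyl carbon can therefore move the number beyond the scatter, which neither of the earlier steps did: no change at the digits printed from compound 1 to compound 2 (within the scatter) concerned a different part of the structure, and a 1.8-fold higher number from compound 2 to compound 3 (0.25 log units; within the scatter), which also removes the (diethylamino)methyl group, stayed within the scatter. The step remains modest, and no measurement available here bears on why the number moves at this place.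

The step swaps the whole group, so the compounds shown do not separate the loss of the diethylamino end from the arrival of the carboxylic acid or of the methyl on the nitrogen; a methyl ester of the acid, or the same chain with a hydrogen in place of that methyl, would speak to this. Also open, as far as these compounds go, is whether (carboxymethyl)(methyl)amino gives a step of similar size alongside the 1-hydroxy-2,2-dimethylpropyl group of compound 2.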